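A few compounds are considered here, and "the series" means these few. Any claim that something is new, unique, unknown or untested is made for them only; others in the source may bear on it.

Compound 1, `O=C(CCSc1nnc(-c2ccncc2)s1)Nc1c(Cl)cccc1Cl`, gives 12600 nM in an ADME assay on HepG2 cells (Homo sapiens) for cytotoxicity, with a stated time of 3 days; a higher number here means that more compound is tolerated, a lower number that less compound is tolerated.
Compound 2, `O=C(CCSc1nnc(-c2ccncc2)s1)Nc1ccccc1Cl`, gives > 50000 nM in this assay, which is a limit of the assay and not a number.
Compound 3, `CC(CSc1nnc(-c2ccncc2)s1)C(=O)Nc1c(Cl)cccc1Cl`, gives > 50000 nM in this assay, again a limit rather than a number.

Compound 3 therefore stands at the upper edge of what the assay reports, and it shares that position with compound 2, since (the limit of > 50000 nM in this assay, at which 2 of the 3 values shown sit). Compound 4, `CC(CSc1nnc(-c2ccncc2)s1)C(=O)Nc1ccccc1Cl`, differs from compound 3 by hydrogen in place of chloro on an aromatic carbon, the same exchange of a chloro for a hydrogen that separates compound 1 from compound 2. Within the data shown here, two measured steps bear on the change. From compound 1 to compound 2, the identical exchange produced an at least 3.9-fold higher number from compound 1 to compound 2 (0.59 log units; beyond the scatter). From compound 1 to compound 3, the methyl on the chain produced an at least 3.9-fold higher number from compound 1 to compound 3 (0.59 log units; beyond the scatter), leaving compound 3 already at the limit. With compound 3 at the limit and the chloro-to-hydrogen step having only ever raised the number, compound 4 is expected to remain at or beyond that limit, so that the step that the limit leaves unreadable from compound 3 to compound 4 is expected to show no change beyond the scatter. Compound 4 is accordingly estimated at 60000 nM, within 30000 nM to 120000 nM, most likely reported again as a limit.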

Compound 4, half-maximal cytotoxic concentration: > 50000 nM
Compound 4 ended at the assay's limit (the forecaster's own chance of this, stated with the estimate: 75%); the middle value is on the limit's open side.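

Compound 4 sits at the same limit as compound 2 and compound 3 in this assay, so neither the step from compound 3 to compound 4 nor the step from compound 2 to compound 4 can be read: the limit of > 50000 nM in this assay, at which 3 of the 4 values shown sit.

The compounds shown leave open how far compound 2, compound 3 and compound 4 lie past that limit.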